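Series notes: distal carboxyphenyl ring, step from compound 2 to compound 4

A few compounds are considered here, and "the series" means these few. Any claim that something is new, unique, unknown or untested is made for them only; others in the source may bear on it.

In an assay on HEK293 cells for positive allosteric modulation of metabotropic glutamate receptor 3 (Rattus norvegicus), read by thallium flux, with a stated time of 2.5 min (a higher number here means a larger maximal response, a lower number a smaller maximal response), compound 2 `Cc1c(OCCCCOc2ccc(C(=O)O)cc2)ccc(C(=O)CC2CCCC2)c1O` gives 26.7%, the lowest of the three numbers measured; compound 1 `Cc1c(OCCCCOc2ccc(C(=O)O)cc2)ccc(C(=O)CC(C)C)c1O` gives 51.9% and compound 3 `Cc1c(OCCCCOc2ccc(C(=O)O)cc2F)ccc(C(=O)CC(C)C)c1O` gives 67.7%. The move from compound 1 to compound 2 was a number 25.2 percentage points lower from compound 1 to compound 2 (beyond the scatter), and the move from compound 1 to compound 3 was a number 15.8 percentage points higher from compound 1 to compound 3 (beyond the scatter). Compound 4 `Cc1ccc(C(=O)O)cc1OCCCCOc1ccc(C(=O)CC2CCCC2)c(O)c1C` differs from compound 2 in that (5-carboxy-2-methylphenyl in place of 4-carboxyphenyl on an oxygen on a saturated carbon). Among the measured compounds shown here, no measured step alters this ring in the same way; the only measured change on it, adding fluoro, was modest. The step is therefore expected to be a number 5.3 percentage points higher from compound 2 to compound 4 (within the scatter), most likely within the scatter. Compound 4 is estimated at 32%, between 15% and 58%.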

Compound 4, largest response reached (reported as percent of maximum), in percent of the reference or control that the assay uses: 26.9%
For compound 4 the middle estimate is 5.1 percentage points above the measured one; the range from low to high includes it.
By their numbers in this assay, from the lowest: compounds 2 and 4 (each within the scatter of the next); then compound 1; then compound 3.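

In this assay the change to 5-carboxy-2-methylphenyl in place of 4-carboxyphenyl gives a number 0.2 percentage points higher from compound 2 to compound 4 (within the scatter) on the cyclopentyl side chain. This ring therefore accepts a change larger than the fluoro of compound 3 without a step beyond the scatter, though the low number of compound 2 is not raised. No available data explain this result.

As far as these compounds go, whether the same change holds with the isopropyl side chain of compound 1 stays open. So does whether a tetrazole or an amide could stand in place of the carboxylic acid on this ring.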